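The source may hold more compounds than are shown below. What is called first, only, known or untested is meant among the compounds shown, and "the series" means these compounds.

In a functional assay on GOTO cells (Homo sapiens) for cytotoxicity, read by MTT assay, with a stated time of 3 days (on this read-out higher numbers stand for weaker inhibition and lower numbers for stronger inhibition), three compounds sharing one core have been measured. Compound 1 `N#Cc1c(NN)nc(SCc2nc3ccccc3[nH]2)nc1-c1ccccc1` gives 2.68 nM, compound 2 `N#Cc1c(Nc2ccccn2)nc(SCc2nc3ccccc3[nH]2)nc1-c1ccccc1` gives 2.5 nM and compound 3 `N#Cc1c(Nc2nccs2)nc(SCc2nc3ccccc3[nH]2)nc1-c1ccccc1` gives 5.1 nM. Compound 3 therefore lies within the scatter of compound 1, with a 1.9-fold higher number from compound 1 to compound 3 (0.28 log units; within the scatter), and stands apart from compound 2 only modestly, with a 2.0-fold higher number from compound 2 to compound 3 (0.31 log units; beyond the scatter).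

Compound 4 `CN1CCN(c2nc(SCc3nc4ccccc4[nH]3)nc(-c3ccccc3)c2C#N)CC1` changes the same position, on an aromatic carbon ortho to a cyano group: 4-methylpiperazin-1-yl in place of (1,3-thiazol-2-yl)amino on an aromatic carbon. For the measured compounds named here, no measured step brings in a 4-methylpiperazin-1-yl group. Every measured step only exchanges one group on a nitrogen for another, so they bear on this change indirectly. Those steps remained small, as with a 1.1-fold lower number from compound 1 to compound 2 (0.03 log units; within the scatter) and the two steps to compound 3 above. A step beyond the scatter is therefore not expected in this assay, although the range must stay wide for a group of a new kind. The expected value for compound 4 is 5 nM, within an estimated range of 1.5 nM to 18 nM. The estimated step is a 1.0-fold lower number from compound 3 to compound 4 (0.01 log units; within the scatter).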

Compound 4, half-maximal inhibitory concentration: 3.37 nM
Beside the measured number, compound 4's estimate is 1.5-fold (0.17 log units) above it; low and high end bracket the measured number.
By their numbers in this assay, from the lowest: compounds 2, 1, 4 and 3 (each within the scatter of the next, the first and the last beyond it).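

In this assay the change at this position, on an aromatic carbon ortho to a cyano group, stays small whichever earlier group it replaces: a 1.5-fold lower number from compound 3 to compound 4 (0.18 log units; within the scatter) and a 1.3-fold higher number from compound 2 to compound 4 (0.13 log units; within the scatter) and also a 1.3-fold higher number from compound 1 to compound 4 (0.10 log units; within the scatter) all lie within the scatter. Compound 4 shows that the position accepts a group joined through a six-membered non-aromatic ring with 0 hydrogen-bond donors, so among these compounds a hydrogen-bond donor on the group at this position is not needed for a number in this range. What lies behind this tolerance cannot be said from the information available.

The compounds shown leave open whether the methyl group of compound 4 matters, which a plain piperazin-1-yl or a morpholin-4-yl group would test. They also leave open whether a carboxylic acid or a longer alkyl chain at this position would stay in the same range.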